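The compounds below may be only part of what the source reports. "The series", "measured", "known", "first", "only" and "open" are said of these compounds alone.

Measured compounds:
compound 1, `Cn1c(/C=C/C(=O)c2ccc(O)cc2O)cc(Br)c1Br`: 3530 nM
compound 2, `Cn1c(/C=C/C(=O)c2ccc(O)cc2)cc(Br)c1Br`: 6000 nM
compound 3, `Cn1c(-c2cc(-c3ccccc3)no2)cc(Br)c1Br`: 16600 nM

These numbers come from a functional assay on Caco-2 cells (Homo sapiens) for cytotoxicity, read by MTT assay, with stated times of 6 h and 48 h; on this read-out lower numbers stand for stronger inhibition and higher numbers for weaker inhibition. Compound 1 differs from compound 2 in one place, (hydroxy in place of hydrogen on an aromatic carbon), and that change made a step of a 1.7-fold lower number from compound 2 to compound 1 (0.23 log units; within the scatter). Compound 3 is built on a different core; how that core differs from the core of compound 2 is not broken down here, and compound 3 gives the highest number of the three.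

Compound 4, `Cn1c(-c2cc(-c3ccccc3O)no2)cc(Br)c1Br`, is not yet measured. It differs from compound 3 by hydroxy in place of hydrogen on an aromatic carbon. This is the same kind of change as from compound 2 to compound 1, but the surroundings are not identical: in compound 1 the entering group is also meta to a hydroxy group, whereas in compound 4 it is not. Because the earlier step was a 1.7-fold lower number from compound 2 to compound 1 (0.23 log units; within the scatter), the step from compound 3 to compound 4 is expected to be of similar size, a 1.7-fold lower number from compound 3 to compound 4 (0.22 log units; within the scatter). Compound 4 is therefore estimated at 10000 nM, most likely between 4000 nM and 25000 nM.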

Compound 4, half-maximal inhibitory concentration: >= 100000 nM
Compound 4: no number, only a limit (the forecaster's own chance of this, stated with the estimate: 5%); at least 10-fold (1.00 log units) between middle value and limit.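

In this assay, hydroxy in place of hydrogen on an aromatic carbon did not behave the same way on the two cores: the same change on two cores in this assay, a 1.7-fold lower number (0.23 log units; within the scatter) from compound 2 to compound 1 and an at least 6.0-fold higher number (0.77 log units; beyond the scatter) from compound 3 to compound 4, at least 10-fold (1.01 log units) apart, beyond the scatter of two such steps On the core of compound 3, the change gave an at least 6.0-fold higher number from compound 3 to compound 4 (0.77 log units; beyond the scatter), so a step seen on one core cannot be assumed to hold on the other in this series. Compound 4 gives >= 100000 nM, which is a limit of the assay and not a number, and with one pair per core the data show neither the full size of this step nor why the two steps differ.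

The compounds shown leave open whether a methoxy group or an amine in the same place on the core of compound 3 would give a result like that of hydroxy. They also leave open how hydroxy would behave at other places on that ring.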